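Moving the fluorine: a small shift expected

This account rests on a few compounds, and the source may have more. Where it says the series, first, only, none or still open, it means among the compounds named here.

Measured in a functional assay on cells (Cancer cell lines, Homo sapiens) for inhibition, read by MTT assay, with a stated time of 48 h; a lower number here means a stronger inhibitor, a higher number a weaker inhibitor:
- Compound 1 `O=C(/C=C/c1ccccc1Br)NNC(=O)c1ccc2c(c1)OCCO2` gives 2110 nM
- Compound 2 `O=C(/C=C/c1ccc(F)cc1)NNC(=O)c1ccc2c(c1)OCCO2` gives 990 nM

Compound 2 holds the lower of the two numbers, so it is the stronger inhibitor of this pair. Compound 3 `O=C(/C=C/c1ccccc1F)NNC(=O)c1ccc2c(c1)OCCO2` differs from it in one group (2-fluorophenyl in place of 4-fluorophenyl on a double-bonded chain carbon bound to a double-bonded chain carbon) and keeps the rest of the structure.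

Among the measured compounds shown here, one measured step bears on this change (a 2.1-fold lower number from compound 1 to compound 2 (0.33 log units; beyond the scatter)) and it is modest. For the measured compounds named here, that step swapped 2-bromophenyl for 4-fluorophenyl, so it mixes two differences, and no measured pair isolates the move of the fluorine alone. Compound 3 keeps the fluorine of compound 2 yet, as 2-fluorophenyl, matches the 2-bromophenyl of compound 1 (2110 nM) in its numbering. A small rise in the number is therefore expected in this assay (a 1.4-fold higher number from compound 2 to compound 3 (0.15 log units; within the scatter)) and it may stay within the usual scatter. For compound 3 the estimated value is 1400 nM with an expected range from 700 nM to 2800 nM in this estimate.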

Compound 3, half-maximal inhibitory concentration: 4510 nM
Estimate against measurement, compound 3: 3.2-fold (0.51 log units) below, outside the stated range (above it).
By their numbers in this assay, from the lowest: compound 2; then compound 1; then compound 3.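

In this assay, among the compounds shown here, the step of a 4.6-fold higher number from compound 2 to compound 3 (0.66 log units; beyond the scatter) is the first to isolate the move of the fluorine, since 2-fluorophenyl replaces 4-fluorophenyl with the same atoms joined differently. Where the fluorine sits on the phenyl ring therefore matters in this series, and compound 2 keeps the lowest number of the three. Fluoro in place of bromo on an aromatic carbon gives a 2.1-fold higher number from compound 1 to compound 3 (0.33 log units; beyond the scatter), so the identity of the halogen also changes the result when its place stays the same.

No available evidence explains either difference. The compounds shown leave open how 4-bromophenyl would compare with 4-fluorophenyl, and whether a methoxy group or an amine on the same ring would give a lower number than compound 2.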